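This account rests on a few compounds, and the source may have more. Where it says the series, first, only, none or still open, it means among the compounds named here.

Measured so far in an assay on isolated protein for inhibition of 2-Hydroxyacid oxidase 2 (Homo sapiens), tested at 10 uM; on this read-out higher numbers stand for a stronger effect at the one concentration tested and lower numbers for a weaker effect:
compound 1 `Cc1n[nH]c(C(=O)O)c1Cc1ccc(C(F)(F)F)cc1` gives 12%
compound 2 `Cc1n[nH]c(C(=O)O)c1Cc1ccc(C#N)cc1` gives 6%

Compound 2 stands at the lower of the two numbers, with compound 1 as its nearest neighbour, but the step of a number 6 percentage points lower from compound 1 to compound 2 (within the scatter) lies within the scatter, so neither compound can be called the stronger one.

Compound 3 `Cc1n[nH]c(C(=O)O)c1Cc1ccc(C(N)=O)cc1` has not yet been measured. It differs from compound 2 in a single place: carbamoyl in place of cyano on an aromatic carbon. Among the compounds with values here, only one measured step bears on such an exchange on the aromatic carbon, namely a number 6 percentage points lower from compound 1 to compound 2 (within the scatter), and it stayed within the scatter. Within the data shown here, no measured pair exchanges cyano for carbamoyl, so that change itself is untested here. On this basis the step of a number 2 percentage points higher from compound 2 to compound 3 (within the scatter) is expected to remain within the scatter, in no clear direction. Compound 3 is therefore estimated at 8%, with a range from -6% to 24%.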

Compound 3, a percentage reported as inhibition, at one concentration (the size of the read-out at that concentration, not a potency): 8%
The estimate for compound 3 equals the measured number at the digits printed, and the stated range covers the measured number.
By their numbers in this assay, from the lowest: compounds 2, 3 and 1 (each within the scatter of the next).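

In this assay, carbamoyl on this aromatic carbon, para to a large group, brings a hydrogen-bond donor that cyano lacks, yet the change gives only a number 2 percentage points higher from compound 2 to compound 3 (within the scatter). Set against trifluoromethyl, the same group gives a number 4 percentage points lower from compound 1 to compound 3 (within the scatter), so three groups of different make-up at this one position now cannot be told apart on this read-out. No measurement shown here offers a reason for these numbers.

On these data alone, whether an amine or a methylsulfonyl group at this position would separate from these three remains open. So does whether any change elsewhere on the shared core would move the read-out beyond the scatter, since all three compounds differ only at this one place.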